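A Halogen Swap on the Shared Core

This account rests on a few compounds, and the source may have more. Where it says the series, first, only, none or still open, it means among the compounds named here.

Among the measured compounds shown here, compound 3 `COc1ccc(C(=O)/C=C/c2ccc(F)cc2)c2c1C=CC(C)(C)O2` is one of three compounds measured in a functional assay on HepG2 cells (Homo sapiens) for antiproliferative activity, read by MTT assay, with a stated time of 24 h; on this read-out lower numbers stand for stronger inhibition and higher numbers for weaker inhibition. In this assay compound 3 gives > 10000 nM, which is a limit of the assay rather than a number. Compound 1 `COc1cccc(/C=C/C(=O)c2ccc(OC)c3c2OC(C)(C)C=C3)c1` gives > 10000 nM in this assay, likewise a limit. Compound 2 `COc1cc(OC)c(OC)cc1/C=C/C(=O)c1ccc(OC)c2c1OC(C)(C)C=C2` gives > 10000 nM in this assay, also only a limit. For the measured compounds named here, all the measured evidence therefore amounts to the limit of > 10000 nM in this assay, at which 3 of the 3 values shown sit: every value sits at the limit, and the single one-place step, a step that the two limits leave unreadable from compound 1 to compound 3, cannot be read in size or direction. Compound 4 `COc1ccc(C(=O)/C=C/c2ccccc2Cl)c2c1C=CC(C)(C)O2` differs from compound 3 by 2-chlorophenyl in place of 4-fluorophenyl on a double-bonded chain carbon bound to a double-bonded chain carbon. No readable measured step bears on this change, so there is no basis for expecting a step beyond the usual scatter in either direction, and the weight of what is known points to compound 4 returning only a limit once more. The expected step that the limit leaves unreadable from compound 3 to compound 4 is accordingly close to none. Compound 4 is estimated at 15000 nM, with an expected range from 5000 nM to 50000 nM.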

Compound 4, half-maximal inhibitory concentration: > 10000 nM
Compound 4: no number, only a limit (the forecaster's own chance of this, stated with the estimate: 85%); the middle value is on the limit's open side.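

Compound 4 returns only a limit, as do compound 1 and compound 3, so the steps from compound 1 and compound 3 to compound 4 cannot be read in size or direction: the limit of > 10000 nM in this assay, at which 4 of the 4 values shown sit. The compounds shown leave open whether any group at this place on the shared core changes the read-out at all, and in which direction.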